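From Isobutyl to Sec-Butyl at the Edge of Measurement

This account rests on a few compounds, and the source may have more. Where it says the series, first, only, none or still open, it means among the compounds named here.

Of the compounds shown here, three have been tested in a functional assay on CHO-K1 cells (Cricetulus griseus) for inhibition, read by sulforhodamine B assay, with a stated time of 72 h; on this read-out higher numbers stand for weaker inhibition and lower numbers for stronger inhibition. Compound 1 (`CCC(C)NC(=C\C(=O)/C=C/c1ccc(O)c(OC)c1)/C=C/c1ccc(O)c(OC)c1`) reads > 25000 nM, which is a limit and not a number. Compound 3 (`COc1cc(/C=C/C(=O)/C=C(/C=C/c2ccc(O)c(OC)c2)NC2CCCCC2)ccc1O`) reads > 25000 nM, which is also a limit. Going by the values given here, compound 2 (`CC(C)CNC(=C\C(=O)/C=C/c1ccc(O)cc1)/C=C/c1ccc(O)cc1`) gives 23700 nM, the only true number among the three, and the other two readings stop at the limit of > 25000 nM in this assay, at which 2 of the 3 values shown sit.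

Compound 4 (`CCC(C)NC(=C\C(=O)/C=C/c1ccc(O)cc1)/C=C/c1ccc(O)cc1`) has not yet been measured. It departs from compound 2 by one change, sec-butyl in place of isobutyl on an amine nitrogen. The two structures have the same atoms, joined differently.

Among the compounds with values here, only one measured step bears on this change, as it also alters the group on an amine nitrogen. That step is a step that the two limits leave unreadable from compound 1 to compound 3, so it offers no size to carry over. The expectation therefore rests on compound 2 at 23700 nM, and no shift beyond the usual scatter is expected in this assay, in either direction. The expected change is a 1.1-fold lower number from compound 2 to compound 4 (0.05 log units; within the scatter). Compound 4 is estimated at 21000 nM, with an expected range of 12000 nM to 30000 nM. A result reported only as a limit would also fit this expectation.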

Compound 4, half-maximal inhibitory concentration: 15100 nM
Compound 4: middle estimate off by 1.4-fold (0.14 log units), on the high side; low and high end bracket the measured number.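

In this assay, exchanging isobutyl for sec-butyl on an amine nitrogen gives a 1.6-fold lower number from compound 2 to compound 4 (0.20 log units; within the scatter), so these two groups, which have the same atoms joined differently, cannot be told apart on this read-out. Going by these compounds alone, this is the first step at this position that has a size, and it shows that, on the core of compound 2, this rearrangement of a four-carbon group leaves the reading within the usual scatter of repeated measurements. The one earlier step at this nitrogen, cyclohexyl in place of sec-butyl, cannot be read, since compound 1 and compound 3 both give limits and not numbers: the limit of > 25000 nM in this assay, at which 2 of the 4 values shown sit.

What the compounds shown leave open is whether any group on this nitrogen can move the reading beyond the scatter, as a single readable step says nothing about groups further from these two in size or kind. A longer chain such as n-octyl, a benzyl group or a chain ending in a carboxylic acid, placed on the same nitrogen of the core of compound 2, would test this.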